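Thiophene series: ethyl in place of thiophen-3-yl

The source may report more compounds than this note shows. Statements on the series, on what has been measured and on what is new or still open speak of the compounds shown alone.

Going by the values given here, compound 1 `C[C@H]1[C@H](NCc2sccc2-c2ccsc2)C[C@H]2C[C@@H]1C2(C)C` stands highest of the two numbers so far in an ADME assay on MDCK cells (Canis lupus familiaris) for cytotoxicity, read by microscopy, with a stated time of 48 h (on this read-out lower numbers stand for higher toxicity in this test and higher numbers for lower toxicity in this test), where compound 1 gives 12500 nM. Its nearest neighbour is compound 2 `C[C@H]1[C@H](NCc2cc(-c3ccccc3)cs2)C[C@H]2C[C@@H]1C2(C)C`, which in this assay gives 5000 nM, a gap beyond the scatter. Compound 3 `CCc1ccsc1CN[C@@H]1C[C@H]2C[C@@H]([C@H]1C)C2(C)C` differs from compound 1 by ethyl in place of thiophen-3-yl on an aromatic carbon. Among the compounds with values here, no step between measured compounds covers this change, so the direction rests on the change alone; a modest rise, near the scatter, is expected. Compound 3 is estimated at 20000 nM, range 6000 nM to 80000 nM, an expected step of a 1.6-fold higher number from compound 1 to compound 3 (0.20 log units; within the scatter).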

Compound 3, minimum cytotoxic concentration: 25000 nM
For compound 3 the middle estimate is 1.3-fold (0.10 log units) below the measured one; measured number inside the range.
By their numbers in this assay, from the lowest: compound 2; then compounds 1 and 3 (each within the scatter of the next).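

At this position, on an aromatic carbon two ring bonds from the ring sulfur, the thiophen-3-yl ring gives way to ethyl, which has no ring, with a 2.0-fold higher number from compound 1 to compound 3 (0.30 log units; within the scatter) in this assay. For this pair, the aromatic ring at this place is therefore not needed to keep the read-out within the scatter. Nothing on hand gives a reason for this step.

Going by these compounds, how a carboxylic acid, an amine or a chain longer than ethyl would read at this place stays open. So does whether this pair behaves the same way outside this assay.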